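From fluoro to trifluoromethyl at the assay limit

The source may hold more compounds than are shown below. What is called first, only, known or untested is meant among the compounds shown, and "the series" means these compounds.

Measured so far in a functional assay on MDA-MB-436 cells (Homo sapiens) for antiproliferative activity, read by MTT assay, with a stated time of 24 h (a higher number here means a weaker inhibitor, a lower number a stronger inhibitor), each value a limit and not a number:
Compound 1 (`CC(C)(C)c1ccc(S(=O)(=O)NC(CC(=O)O)c2ccccc2)cc1`): > 100000 nM
Compound 2 (`O=C(O)CC(NS(=O)(=O)c1ccc(F)cc1)c1ccccc1`): > 100000 nM
Compound 3 (`O=C(O)CC(NS(=O)(=O)c1ccccc1Br)c1ccccc1`): > 100000 nM

Compound 2 stands where the other two stand, as the limit of > 100000 nM in this assay, at which 3 of the 3 values shown sit, shows, so it has no exact number. Compound 4 (`O=C(O)CC(NS(=O)(=O)c1ccc(C(F)(F)F)cc1)c1ccccc1`) differs from compound 2 by one change (trifluoromethyl in place of fluoro on an aromatic carbon): trifluoromethyl in place of fluoro on an aromatic carbon, para to a large group.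

For the measured compounds named here, two measured steps bear on this change. One is a step that the two limits leave unreadable from compound 1 to compound 2 and also swaps the group on an aromatic carbon. The other is a step that the two limits leave unreadable from compound 2 to compound 3 and puts 2-bromophenyl in place of 4-fluorophenyl on a sulfonyl sulfur. Neither has a size that can be carried over. No step beyond the scatter is therefore expected in this assay, and no direction. This expectation rests on compound 2, whose limit is > 100000 nM in this series. The estimated step is a number no higher from compound 2 to compound 4 (the limit leaves the size open) by this reasoning. For compound 4 the estimated value is 100000 nM with an expected range from 50000 nM to 200000 nM and a report of a limit alone is the likeliest outcome.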

Compound 4, half-maximal inhibitory concentration: 54700 nM
Compound 4: the middle estimate sits 1.8-fold (0.26 log units) above what was measured, within the range that was stated.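

In this assay, for the compounds shown here, compound 4 is the only compound here with an exact number, so this aromatic carbon is a place where changing the group can bring the reading inside the range of the assay. Trifluoromethyl in place of fluoro gives an at least 1.8-fold lower number from compound 2 to compound 4 (0.26 log units; that floor lies within the scatter), and trifluoromethyl in place of tert-butyl gives an at least 1.8-fold lower number from compound 1 to compound 4 (0.26 log units; that floor lies within the scatter). Both steps are only floors, and the steps among the other compounds cannot be read at all, because those compounds rest on a limit: the limit of > 100000 nM in this assay, at which 3 of the 4 values shown sit.

From the compounds shown here alone, how far compound 4 truly lies from compound 1 and compound 2 stays open. So does whether a nitrile, a methoxy group or an amine on the same aromatic carbon would give a number or another limit.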